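This account rests on a few compounds, and the source may have more. Where it says the series, first, only, none or still open, it means among the compounds named here.

Working notes on the series. Within the data shown here, in a functional assay on MCF7 cells (Homo sapiens) for inhibition, with a stated time of 48 h (on this read-out lower numbers stand for stronger inhibition and higher numbers for weaker inhibition), compound 3 `COc1cc(Sc2c[nH]c3ccc(C)cc23)cc(OC)c1OC` reads 16 nM and holds the lowest of the three numbers so far. Compound 1 `COc1cc(Sc2c[nH]c3ccc(Cl)cc23)cc(OC)c1OC` gives 77 nM on the same read-out, and compound 2 `COc1cc(Sc2c[nH]c3ccc(F)cc23)cc(OC)c1OC` gives 160 nM on it.

The next entry is compound 4 `COc1cc(Sc2c[nH]c3ccc(OCCOCc4ccccc4)cc23)cc(OC)c1OC` and it differs from compound 3 in one place. The change is 2-(benzyloxy)ethoxy in place of methyl on an aromatic carbon and amounts to 2-(benzyloxy)ethoxy in place of methyl on an aromatic carbon.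

Among the measured compounds shown here, three measured steps bear on this place, each a swap of one small group for another. Fluoro in place of chloro gives a 2.1-fold higher number from compound 1 to compound 2 (0.32 log units; beyond the scatter) and is modest. Methyl in place of chloro gives a 4.8-fold lower number from compound 1 to compound 3 (0.68 log units; beyond the scatter) and methyl in place of fluoro gives a 10-fold lower number from compound 2 to compound 3 (1.00 log units; beyond the scatter) as the largest step in the set.

For the measured compounds named here, no measured step involves a group of this size, so these steps guide the direction only loosely. Both other groups tried here sit above methyl, so a step to a higher number is expected in this assay at about the size of the largest measured step or beyond. The estimated step is a 16-fold higher number from compound 3 to compound 4 (1.19 log units; beyond the scatter) with wide uncertainty. For compound 4 the expected value is 250 nM within an estimated range from 30 nM to 2000 nM for now.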

Compound 4, half-maximal inhibitory concentration: 260 nM
Compound 4: middle estimate off by 1.0-fold (0.02 log units), on the low side; measured number inside the range.
By their numbers in this assay, from the lowest: compound 3; then compound 1; then compounds 2 and 4 (each within the scatter of the next).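

In this assay this position, on an aromatic carbon of the shared core, accepts a group far larger than any earlier one and the read-out stays within the range of the halogen compounds, yet 2-(benzyloxy)ethoxy does not keep what methyl gives (a 16-fold higher number from compound 3 to compound 4 (1.21 log units; beyond the scatter)). Size alone does not set the order here: with its 11 heavy atoms and six-membered aromatic ring, the new group cannot be separated from a single fluoro atom (a 1.6-fold higher number from compound 2 to compound 4 (0.21 log units; within the scatter)), and only the step from chloro stands beyond the scatter among the halogen comparisons (a 3.4-fold higher number from compound 1 to compound 4 (0.53 log units; beyond the scatter)). No measured evidence on this result explains these steps.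

The compounds shown do not separate the contribution of the ether chain from that of the terminal phenyl ring, so a simple methoxy, a 2-methoxyethoxy or a plain benzyloxy group at this position would be needed to tell them apart. On these data alone, whether the advantage of compound 3 extends to other small carbon groups such as ethyl or trifluoromethyl, or whether an amine at the end of a chain changes the picture, also stays open.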